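This account rests on a few compounds, and the source may have more. Where it says the series, first, only, none or still open, it means among the compounds named here.

Three compounds share one core and differ only in the aryl group on a saturated chain carbon bound to an amine nitrogen. Compound 1 `C#CCN(CCCOc1ccc2ccc(=O)oc2c1)Cc1cccc(F)c1` gives 29300 nM in an ADME assay on isolated protein for inhibition of Amine oxidase [flavin-containing] A (Homo sapiens), read by fluorescence and Amplex Red, with stated times of 15 min and 20 min; a higher number here means a weaker inhibitor, a lower number a stronger inhibitor. Compound 2 `C#CCN(CCCOc1ccc2ccc(=O)oc2c1)Cc1ccc(OC)cc1` gives 60000 nM in this assay, and compound 3 `C#CCN(CCCOc1ccc2ccc(=O)oc2c1)Cc1ccc(F)c(F)c1` gives 49200 nM in this assay. Compound 3 holds the second highest of the three numbers; its nearest neighbour is compound 2, and the gap a 1.2-fold lower number from compound 2 to compound 3 (0.09 log units; within the scatter) lies within the scatter, as does the gap a 1.7-fold higher number from compound 1 to compound 3 (0.23 log units; within the scatter) to compound 1.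

Compound 4 `C#CCN(CCCOc1ccc2ccc(=O)oc2c1)Cc1cccc(OC)c1` is not yet measured. It differs from compound 3 in one place: 3-methoxyphenyl in place of 3,4-difluorophenyl on a saturated chain carbon bound to an amine nitrogen.

Within the data shown here, two measured steps bear on this. The step of a 2.0-fold higher number from compound 1 to compound 2 (0.31 log units; beyond the scatter) exchanged a fluorophenyl for a methoxyphenyl and was modest, while the step of a 1.2-fold lower number from compound 2 to compound 3 (0.09 log units; within the scatter) stayed within the scatter. A methoxyphenyl in place of a difluorophenyl is therefore expected to move the number little, perhaps slightly upward. Compound 4 is expected to give 55000 nM in this assay, with a likely range from 25000 nM to 120000 nM. The expected step of a 1.1-fold higher number from compound 3 to compound 4 (0.05 log units; within the scatter) is thus estimated to stay within the scatter.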

Compound 4, half-maximal inhibitory concentration: 22700 nM
Estimate against measurement, compound 4: 2.4-fold (0.38 log units) above; measured number below the stated range.
By their numbers in this assay, from the lowest: compounds 4, 1, 3 and 2 (each within the scatter of the next, the first and the last beyond it).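

Where the methoxy group sits on the aryl ring matters here: 3-methoxyphenyl in place of 4-methoxyphenyl gives a 2.6-fold lower number from compound 2 to compound 4 (0.42 log units; beyond the scatter) in this assay, so a methoxyphenyl at this place does not in itself bring a high number. The same group in place of 3,4-difluorophenyl gives a 2.2-fold lower number from compound 3 to compound 4 (0.34 log units; beyond the scatter) and thus also moves beyond the scatter, whereas methoxy in place of fluoro on an aromatic carbon gives a 1.3-fold lower number from compound 1 to compound 4 (0.11 log units; within the scatter) and leaves 3-methoxyphenyl and 3-fluorophenyl indistinguishable. No measurement shown accounts for these differences.

Going by these compounds, it remains open whether a chloro or ethoxy group in place of the methoxy of compound 4 would give a similar number. On these data alone, the effect of a pyridine ring in place of its aromatic carbon ring also remains unknown.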